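Cytotoxicity notes: hydroxyl for methoxy on compound 2

The source may report more compounds than this note shows. Statements on the series, on what has been measured and on what is new or still open speak of the compounds shown alone.

Compound 2 `COCc1ccc(Nc2ncc(Cc3c(F)cccc3F)o2)cc1` gives the highest number of the three measured in an ADME assay on MT2 cells (Homo sapiens) for cytotoxicity, read by MTT assay (on this read-out lower numbers stand for higher toxicity in this test and higher numbers for lower toxicity in this test), at 32000 nM. Compound 1 `N#Cc1ccc(Nc2ncc(Cc3c(F)cccc3F)o2)cc1` gives 7400 nM in this assay, and compound 3 `COCc1ccc(Nc2ncc(Cc3c(Cl)cccc3Cl)o2)cc1` gives 8100 nM. Two steps connect them: a 4.3-fold higher number from compound 1 to compound 2 (0.64 log units; beyond the scatter), and a 4.0-fold lower number from compound 2 to compound 3 (0.60 log units; beyond the scatter). Both are modest and both lie beyond the scatter.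

Compound 4 `OCCc1ccc(Nc2ncc(Cc3c(F)cccc3F)o2)cc1` has not been measured in this assay. It differs from compound 2 as follows: hydroxymethyl in place of methoxy on a saturated chain carbon bound to an aromatic carbon. Among the measured compounds shown here, no measured step involves this change; the step from compound 1 to compound 2 touches the same saturated chain carbon but swaps a different group, and the step from compound 2 to compound 3 acts elsewhere. For the measured compounds named here, with no direct precedent, the expectation is that the change from compound 2 to compound 4 stays within the scatter in this assay, with the estimated step being a 1.1-fold lower number from compound 2 to compound 4 (0.03 log units; within the scatter). Compound 4 is therefore expected to give about 30000 nM in this assay, within a range of 12000 nM to 80000 nM.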

Compound 4, half-maximal cytotoxic concentration: 35000 nM
Estimate against measurement, compound 4: 1.2-fold (0.07 log units) below, within the range that was stated.
By their numbers in this assay, from the lowest: compounds 1 and 3 (each within the scatter of the next); then compounds 2 and 4 (each within the scatter of the next).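

In this assay, a 1.1-fold higher number from compound 2 to compound 4 (0.04 log units; within the scatter) shows that 2-hydroxyethyl can stand in place of methoxymethyl, bringing in a hydrogen-bond donor where there was none, without a shift beyond the scatter. The separation from the nitrile also holds for the new group: a 4.7-fold higher number from compound 1 to compound 4 (0.67 log units; beyond the scatter) is close in size to a 4.3-fold higher number from compound 1 to compound 2 (0.64 log units; beyond the scatter), so the result at this aromatic carbon is much the same with either of these two chains. No supporting data on these compounds account for the numbers.

From the compounds shown here alone, whether the change to 2,6-dichlorophenyl, seen as a 4.0-fold lower number from compound 2 to compound 3 (0.60 log units; beyond the scatter), would carry over to compound 4 remains open. Also open, going by these compounds, is how the read-out would respond to a longer chain, an amine or a carboxylic acid in place of the 2-hydroxyethyl group.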